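Chain length and tolerated concentration in a cytotoxicity series

A few compounds are considered here, and "the series" means these few. Any claim that something is new, unique, unknown or untested is made for them only; others in the source may bear on it.

Measured compounds:
compound 1, `CCCCNc1cncc(C(=O)NCc2ccccc2)n1`, 100000 nM
compound 2, `CCCCCCCCNc1cncc(C(=O)NCc2ccccc2)n1`, 4000 nM
compound 3, `O=C(NCc1ccccc1)c1cncc(Cl)n1`, "not determined" (no result reported)

In an ADME assay on MDCK cells (Canis lupus familiaris) for cytotoxicity, read by microscopy, with a stated time of 6 days (a lower number here means that less compound is tolerated, a higher number that more compound is tolerated), compound 1 gives 100000 nM, while compound 2 gives 4000 nM. Going by the values given here, the one step between measured compounds that differ in a single place is a 25-fold lower number from compound 1 to compound 2 (1.40 log units; beyond the scatter). For compound 3 no number was obtained in this assay; it therefore stands nowhere on the scale that compounds 1 and 2 define, and it can serve only as the structural starting point.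

The unmeasured compound is compound 4, `CCCCCCCNc1cncc(C(=O)NCc2ccccc2)n1`. Relative to compound 3 the change is heptylamino in place of chloro on an aromatic carbon. Among the compounds with values here, the resulting compound 4 carries a chain one carbon shorter than that of compound 2 and three carbons longer than that of compound 1, so the step of a 25-fold lower number from compound 1 to compound 2 (1.40 log units; beyond the scatter) is the only measured step that bears on it. That step was large and went toward a lower tolerated concentration as the chain grew, which suggests that compound 4 should lie between compounds 1 and 2 and nearer to compound 2. Compound 4 is accordingly expected to give about 8000 nM in this assay, with a likely range from 2500 nM to 30000 nM.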

Compound 4, minimum cytotoxic concentration: 4000 nM
The estimate for compound 4 lay 2.0-fold (0.30 log units) above the measured number; the measured number falls inside the stated range.
By their numbers in this assay, from the lowest: compounds 2 and 4 (each within the scatter of the next); then compound 1.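

In this assay, trimming the chain of compound 2 to the heptylamino group of compound 4 gives no change at the digits printed from compound 2 to compound 4 (within the scatter), so at this place on the ring, where compound 3 carries chloro, the two longest chains cannot be told apart. The large difference from the shorter chain of compound 1 is already fully present with heptylamino (a 25-fold lower number from compound 1 to compound 4 (1.40 log units; beyond the scatter)), which the earlier pair of chains could not show. Across these three compounds the number therefore does not fall evenly with chain length, and compound 2 goes against such a trend by standing within the scatter of compound 4. Nothing shown here offers a measured explanation for this behaviour.

The compounds shown leave open where between the chain of compound 1 and heptylamino the fall takes place, which pentylamino and hexylamino chains would locate, and whether a still longer chain would stay level or move further. They also leave open whether a chain of this length ending in an amine or a carboxylic acid would give a similar number.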